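Carboxymethyl on the Ring Nitrogen: Cytotoxicity of Compound 3

A few compounds are considered here, and "the series" means these few. Any claim that something is new, unique, unknown or untested is made for them only; others in the source may bear on it.

Measured so far:
compound 1, `COc1ccc2cc(-c3ccccc3)c(O)nc2c1`, 10000 nM
compound 2, `COc1ccc(-c2cc3c(OC)cc(OC)cc3n(C)c2=O)cc1`, 10000 nM

Of the compounds shown here, two have been tested in a functional assay on A-427 cells (Homo sapiens) for cytotoxicity, read by colorimetric assay and MTT assay; on this read-out higher numbers stand for weaker inhibition and lower numbers for stronger inhibition. Compound 1, built as `COc1ccc2cc(-c3ccccc3)c(O)nc2c1`, gives 10000 nM in this assay. Compound 2, with the structure `COc1ccc(-c2cc3c(OC)cc(OC)cc3n(C)c2=O)cc1`, gives 10000 nM in the same assay, so it stands level with compound 1 within the scatter; the two values show no difference in potency.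

Compound 3, `COc1ccc(-c2cc3c(OC)cc(OC)cc3n(CC(=O)O)c2=O)cc1`, has not yet been measured. Its structure is reached from compound 2 by one change:

carboxy in place of hydrogen on a saturated chain carbon bound to an aromatic nitrogen

Going by the values given here, no step between the measured compounds offers a guide to this change, so the expectation rests on compound 2 alone. Compound 3 is expected to stay at about the level of compound 2, with the step of no change at the digits printed from compound 2 to compound 3 (within the scatter) amounting to nothing beyond the scatter. The estimate for compound 3 in this assay is 10000 nM, with a range from 4000 nM to 25000 nM.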

Compound 3, half-maximal inhibitory concentration: 10000 nM
Estimate against measurement, compound 3: no gap at the digits printed; the measured number falls inside the stated range.
By their numbers in this assay, from the lowest: compounds 1, 2 and 3 (each within the scatter of the next).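

In this assay, going by these compounds alone, the change from methyl to carboxymethyl on the aromatic nitrogen gives the first step that can be read at this position, and it reads no change at the digits printed from compound 2 to compound 3 (within the scatter). The earlier compounds shown here could not show this, since compound 1 and compound 2 offered no step, and the pair now shows that carboxy on this saturated chain carbon leaves the read-out where compound 2 had it. Nothing at hand bears on why this read-out holds across the change.

The compounds shown leave open whether a methyl ester or a primary amide in place of carboxy, or an amine on a longer chain at the same place, would read any differently from compound 3 at 10000 nM. Going by these compounds, they also offer no step beyond the scatter at this position, so it remains unknown whether any group placed here can move the value at all.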